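A few compounds are considered here, and "the series" means these few. Any claim that something is new, unique, unknown or untested is made for them only; others in the source may bear on it.

Compound 1 `C=C(C)C(=O)c1ccc(OCc2nc(-c3ccc4ccccc4c3)cs2)c(C)c1C` gives 11.3% in an assay on HL-60 cells for inhibition of glutathione S-transferase P (Homo sapiens), read by spectrophotometry, tested at 5 uM; on this read-out higher numbers stand for more inhibition at the one concentration tested (going by the name of the read-out) and lower numbers for less inhibition.
Compound 2 `C=C(C)C(=O)c1ccc(OCc2nc(-c3ccc(C(F)(F)F)cc3)cs2)c(C)c1C` gives 3.6% in this assay.
Compound 3 `C=C(CC)C(=O)c1ccc(OCc2nc(-c3ccc4ccccc4c3)cs2)cc1Cl` gives 9.5% in this assay.

Compound 4 `C=C(CC)C(=O)c1ccc(OCc2nc(-c3ccc(C(F)(F)F)cc3)cs2)cc1Cl` has not yet been measured in this assay. It stands to compound 3 as compound 2 stands to compound 1: the change is 4-(trifluoromethyl)phenyl in place of naphthalen-2-yl on an aromatic carbon, and for the measured pair it is 4-(trifluoromethyl)phenyl in place of naphthalen-2-yl on an aromatic carbon, with the place described in the same words, so it is the same change, made twice among these four compounds. The difference between the core of compound 3 and the core of compound 1 is not broken down here. The measured instance of the change gave a number 7.7 percentage points lower from compound 1 to compound 2 (within the scatter), a step that stays within the scatter of repeated measurements, so compound 1 and compound 2 cannot be told apart with confidence. Compound 3 likewise differs from each of compound 1 and compound 2 by less than the scatter, and all three measured numbers are small for a read-out of this kind.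

Going by the values given here, for compound 4, the expectation rests on the one measured instance of the change, the step of a number 7.7 percentage points lower from compound 1 to compound 2 (within the scatter), applied to compound 3 with its value 9.5%. The expected step is a number 6.5 percentage points lower from compound 3 to compound 4 (within the scatter), of about the same size and direction as the earlier one, though a single step within the scatter is a weak guide. Compound 4 is accordingly estimated at 3% in this assay. The expected range for compound 4 runs from -6% to 12%. That range is wide because the earlier step of a number 7.7 percentage points lower from compound 1 to compound 2 (within the scatter) itself lies within the scatter.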

Compound 4, a percentage reported as inhibition, at one concentration (the size of the read-out at that concentration, not a potency): 19.7%
Beside the measured number, compound 4's estimate is 16.7 percentage points below it, outside the stated range (above it).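

In this assay, 4-(trifluoromethyl)phenyl in place of naphthalen-2-yl on the aromatic carbon gave a number 10.2 percentage points higher from compound 3 to compound 4 (beyond the scatter), so the step seen on the core of compound 1 cannot be taken as a fixed increment for this change in this series. The two instances do not agree, and the gap between them is larger than repeated measurements would explain: the same change on two cores in this assay, a number 7.7 percentage points lower (within the scatter) from compound 1 to compound 2 and a number 10.2 percentage points higher (beyond the scatter) from compound 3 to compound 4, 17.9 percentage points apart, beyond the scatter of two such steps This shows that the result of the swap depends on the core that carries it, but it does not show a firm reversal of sign, as the earlier step lies within the scatter and only the later step and the gap between the two lie beyond it; with two instances and a single tested concentration, it also gives no general rule and no measure of potency.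

Still open, going by these compounds, is which of the differences between the two cores governs the step, as the difference between them has not been broken down into single changes. Also open, on these data alone, is how the same two cores would respond if the aromatic carbon carried a phenyl ring bearing a nitrile, an amine or a carboxylic acid in place of the trifluoromethyl group.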